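This account rests on a few compounds, and the source may have more. Where it says the series, first, only, none or still open, it means among the compounds named here.

Measured compounds:
Compound 1, `COc1ccc(NC2=CC(=O)c3c(nc4n3[C@H]3OC[C@@H](O)[C@H]3OC4)C2=O)cc1`: in a functional assay on MCF7 cells (Homo sapiens) for inhibition, read by sulforhodamine B assay (a lower number here means a stronger inhibitor, a higher number a weaker inhibitor), compound 1 gives 4470 nM.
Compound 2, `O=C1C(NC2CCCCC2)=CC(=O)c2c1nc1n2[C@H]2OC[C@@H](O)[C@H]2OC1`: in this assay compound 2 reaches only the limit > 16000 nM, not a number.

Compound 2 thus stands at the edge of what this assay reports, namely (the limit of > 16000 nM in this assay, at which 1 of the 2 values shown sits), so its true value is not known. Compound 3, `O=C1C(N2CCCC2)=CC(=O)c2c1nc1n2[C@H]2OC[C@@H](O)[C@H]2OC1`, has not been measured. It differs from compound 2 by pyrrolidin-1-yl in place of cyclohexylamino on a double-bonded ring carbon. Among the compounds with values here, only one measured step exists, and it alters the same amine group: an at least 3.5-fold higher number from compound 1 to compound 2 (0.55 log units; beyond the scatter). That step moved the series from a numbered value to a limit, and nothing in the data shows a change at this position improving the number. The change to compound 3 is of the same kind, an alteration at the amine, with a small saturated ring staying in place. No step beyond the scatter is therefore expected in this assay, in either direction, and compound 3 is expected to remain at or near the limit. The estimate for compound 3 is 20000 nM, within 6000 nM to 60000 nM, which means an expected step that the limit leaves unreadable from compound 2 to compound 3.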

Compound 3, half-maximal inhibitory concentration: > 16000 nM
Compound 3 was reported as a limit; the forecaster's own chance of this, stated with the estimate: 65%; the middle value does not contradict the limit.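

In this assay, pyrrolidin-1-yl in place of (4-methoxyphenyl)amino on a double-bonded ring carbon brings an at least 3.5-fold higher number from compound 1 to compound 3 (0.55 log units; beyond the scatter). Until now only the cyclohexylamino group had shown such a step, and the new result shows that it is not confined to that one group: a five-membered non-aromatic ring, attached through its own nitrogen and with 0 hydrogen-bond donors, goes the same way, so among the three compounds only compound 1, with its (4-methoxyphenyl)amino group, gives a number. Compound 2 and compound 3 are both reported only as limits, so the step between them cannot be read and the two groups cannot be ranked: the limit of > 16000 nM in this assay, at which 2 of the 3 values shown sit.

Going by these compounds, whether a phenylamino group without the methoxy, or a benzylamino group, would keep a number in this assay remains open, and so does which part of the (4-methoxyphenyl)amino group matters at this position. Also open, on these data alone, is where the true values of compound 2 and compound 3 lie beyond the limit, and whether a morpholin-4-yl group or a piperidin-1-yl group would behave as pyrrolidin-1-yl does.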